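The compounds below may be only part of what the source reports. "The series", "measured", "known", "first", "only" and "open" are said of these compounds alone.

In a functional assay on MKN-45 cells (Homo sapiens) for cytotoxicity, read by MTT assay, with a stated time of 72 h (on this read-out higher numbers stand for weaker inhibition and lower numbers for stronger inhibition), the three measured compounds give the following numbers.

Compound 1 `CN(C)CCCNc1nc(-c2ccc(NC(=O)Nc3ccccc3Cl)cc2)nc2ccsc12`: 690 nM
Compound 2 `CCN(CC)CCCNc1nc(-c2ccc(NC(=O)Nc3ccccc3)cc2)nc2ccsc12`: 980 nM
Compound 3 `CCN(CC)CCCNc1nc(-c2ccc(NC(=O)Nc3ccccc3Cl)cc2)nc2ccsc12`: 390 nM

Compound 3 has the lowest number of the three. Its step from compound 1, a 1.8-fold lower number from compound 1 to compound 3 (0.25 log units; within the scatter), lies within the scatter, whereas a 2.5-fold lower number from compound 2 to compound 3 (0.40 log units; beyond the scatter) lies beyond it. Compound 4 `CCN(CC)CCNc1nc(-c2ccc(NC(=O)Nc3ccccc3Cl)cc2)nc2ccsc12` differs from compound 3 by diethylamino in place of (diethylamino)methyl on a saturated chain carbon, two bonds along the chain from a nitrogen on an aromatic ring. Neither measured step concerns the chain: one swaps the amine substituents, the other adds chloro, so nothing measured bears directly on shortening the chain. With no guide to direction, the step of a 1.2-fold higher number from compound 3 to compound 4 (0.06 log units; within the scatter) is expected to stay within the scatter. Compound 4 is therefore estimated at 450 nM, in a range from 150 nM to 1400 nM.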

Compound 4, half-maximal inhibitory concentration: 750 nM
The estimate for compound 4 lay 1.7-fold (0.22 log units) below the measured number; the measured number falls inside the stated range.
By their numbers in this assay, from the lowest: compounds 3, 1, 4 and 2 (each within the scatter of the next, the first and the last beyond it).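

Going from 3-(diethylamino)propyl to 2-(diethylamino)ethyl is the first change to the chain length, and it gives a 1.9-fold higher number from compound 3 to compound 4 (0.28 log units; within the scatter) in this assay, so this shortening shows no clear effect. A step that changes the chain length and the amine substituents together, a 1.1-fold higher number from compound 1 to compound 4 (0.04 log units; within the scatter), also stays within the scatter. No available evidence explains these numbers. As far as these compounds go, whether a longer chain such as 4-(diethylamino)butyl, or morpholine in place of diethylamino, would move the number beyond the scatter remains open.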